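This account rests on a few compounds, and the source may have more. Where it says the series, first, only, none or still open, it means among the compounds named here.

Values in a functional assay on the whole organism for agonist activity, with Mus musculus as the target; on this read-out higher numbers stand for an effect only at larger amounts of compound and lower numbers for an effect already at smaller amounts:
Compound 1 `CC(=O)N(C)C(C)C#CCn1ccnc1`: 3 mg/kg.
Compound 2 `COC(=O)N(C)CC#CCn1ccnc1`: 4.5 mg/kg.
Compound 3 `COC(=O)N(C)CC#CCn1cncc1C`: > 100 mg/kg, a limit of the assay.

Compound 2 with 4.5 mg/kg lies within the scatter of compound 1, so the two form one level with no order between them. Compound 3 stands only at a limit: the limit of > 100 mg/kg in this assay, at which 1 of the 3 values shown sits.

Compound 4 `COC(=O)N(C)C(C)C#CCn1ccnc1` is compound 2 with one change: methyl in place of hydrogen on a saturated chain carbon bound to an amide-type nitrogen and a triple-bonded carbon.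

Among the compounds with values here, the only measured single-place step is an at least 22-fold higher number from compound 2 to compound 3 (1.34 log units; beyond the scatter). It is large, but that methyl sits on an aromatic carbon, not on the chain, so it bears only weakly on this change. Closer evidence is compound 1 at 3 mg/kg, which carries methyl on the matching chain carbon, though it differs from compound 4 elsewhere. On these data alone, no step beyond the scatter is therefore expected, though the upper side stays open given the size of the step to compound 3.

The expected step in this assay is a 1.1-fold higher number from compound 2 to compound 4 (0.05 log units; within the scatter).
For compound 4 the estimated value is 5 mg/kg, with an expected range of 1.5 mg/kg to 25 mg/kg.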

Compound 4, dose for half-maximal effect: 8 mg/kg
Compound 4: the middle estimate sits 1.6-fold (0.20 log units) below what was measured; the measured number falls inside the stated range.
By their numbers in this assay, from the lowest: compounds 1, 2 and 4 (each within the scatter of the next, the first and the last beyond it). At a limit, above all of these: compound 3.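

In this assay, within the data shown here, methyl in place of hydrogen on a saturated chain carbon bound to an amide-type nitrogen and a triple-bonded carbon gives a 1.8-fold higher number from compound 2 to compound 4 (0.25 log units; within the scatter), so this chain position tolerates the methyl, and the large step seen with methyl on an aromatic carbon has no counterpart here. Among these compounds, with that chain methyl in place, methoxy in place of methyl on a carbonyl carbon gives a 2.7-fold higher number from compound 1 to compound 4 (0.43 log units; beyond the scatter), a modest step and the first single-place reading of the carbonyl substituent. Nothing given here accounts for either step.

On these data alone, whether the same chain carbon also accepts ethyl or a hydroxyl group remains open. As far as these compounds go, it is equally open how an amine or ethoxy in place of methoxy on the carbonyl carbon would read out.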